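This account rests on a few compounds, and the source may have more. Where it says the series, first, only, none or still open, it means among the compounds named here.

Values in a functional assay on NCI-H460 cells (Homo sapiens) for cytotoxicity, read by sulforhodamine B assay, with a stated time of 48 h, tested at 0.1 uM (a lower number here means a stronger effect, a higher number a weaker effect of the compound at the concentration tested), for the measured members of the series:

- compound 1, `COc1cc(-c2cc(/C=C/C(=O)c3ccc(Cl)c(Cl)c3)[nH]n2)cc(OC)c1OC`: 105%
- compound 2, `COc1ccc(-c2cc(/C=C/C(=O)c3ccc(N)cc3)[nH]n2)cc1OC`: 100%
- compound 3, `COc1ccc(-c2cc(/C=C/C(=O)c3cc(OC)c(OC)c(OC)c3)[nH]n2)cc1OC`: 100%

Compound 1 stands highest of the three numbers, but compound 2 and compound 3 each sit lower only within the usual scatter, so the three cannot be ordered and none of them is set apart. All three read close to an unchanged cell population at the concentration tested. For the measured compounds named here, no pair of measured compounds differs in one place only, so no single-point step size is available.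

Compound 4, `COc1ccc(C(=O)/C=C/c2cc(-c3cc(OC)c(OC)c(OC)c3)n[nH]2)cc1OC`, is the next compound to be measured in this assay. It differs from compound 1 by 3,4-dimethoxyphenyl in place of 3,4-dichlorophenyl on a carbonyl carbon. Compound 3, which also carries methoxy substitution on the aryl at the carbonyl, gives 100%, and compound 1 with the 3,4-dichlorophenyl gives 105%, so the aryl on the carbonyl has so far made no difference beyond the scatter. The step from compound 1 to compound 4 is therefore expected to be none beyond the scatter, a number 5 percentage points lower from compound 1 to compound 4 (within the scatter). Compound 4 is estimated at 100%, with a range from 86% to 112%.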

Compound 4, a percentage reported as activity, at one concentration (the size of the read-out at that concentration, not a potency): 101%
For compound 4 the middle estimate is 1 percentage points below the measured one; the range from low to high includes it.
By their numbers in this assay, from the lowest: compounds 2, 3, 4 and 1 (each within the scatter of the next).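

In this assay, for the compounds shown here, 3,4-dimethoxyphenyl in place of 3,4-dichlorophenyl on a carbonyl carbon gives a number 4 percentage points lower from compound 1 to compound 4 (within the scatter) and is the first step that changes one place only. On the core of compound 1, this position therefore accepts an exchange of two chlorine atoms for two methoxy groups, with two hydrogen-bond acceptors entering, without a change in the read-out beyond the scatter at this single concentration. No measurement accompanies this result that could account for it.

As far as these compounds go, it remains open whether a carboxylic acid on the phenyl ring, or a saturated cyclohexyl ring replacing that ring on the carbonyl carbon, would move the read-out. The compounds shown also leave open whether this step stays as small at any concentration where the series produces a clear cytotoxic effect.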